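Amino-pyridine variation on a shared imidazole-bearing core

A few compounds are considered here, and "the series" means these few. Any claim that something is new, unique, unknown or untested is made for them only; others in the source may bear on it.

Working notes on a small series around one shared core. Compound 1 `CSc1nc(-c2ccc(F)cc2)c(-c2ccnc(OC(C)CCCC(C)C)c2)[nH]1`, compound 2 `CSc1nc(-c2ccc(F)cc2)c(-c2ccnc(NC3CCCCC3C)c2)[nH]1` and compound 3 `CSc1nc(-c2ccc(F)cc2)c(-c2ccnc(NCc3cccnc3)c2)[nH]1` have been run in a functional assay on blood (Homo sapiens) for inhibition; a higher number here means a weaker inhibitor, a lower number a stronger inhibitor. Compound 2 gives 136 nM. Within the data shown here, for compound 1 the entry reads "not determined" (no result reported), and for compound 3 the entry reads "not determined" (no result reported), so compound 3 stands without a number, and no step between measured compounds can be drawn. Compound 4 `CCC(Nc1cc(-c2[nH]c(SC)nc2-c2ccc(F)cc2)ccn1)c1ccccc1` is to be measured next. It differs from compound 3 as follows: 1-phenylpropyl in place of (pyridin-3-yl)methyl on a nitrogen on an aromatic ring. Among the measured compounds shown here, with no measured step to lean on, the expectation for compound 4 rests on compound 2 alone; the value is expected to sit near that of compound 2, because compound 2 gives 136 nM. Compound 4 is estimated at 150 nM, with a range of 40 nM to 600 nM.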

Compound 4, half-maximal inhibitory concentration: 7640 nM
The estimate for compound 4 lay 51-fold (1.71 log units) below the measured number; the measured number lies above the stated range.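

In this assay the group on a nitrogen on an aromatic ring matters greatly: 1-phenylpropyl in place of 2-methylcyclohexyl gives a 56-fold higher number from compound 2 to compound 4 (1.75 log units; beyond the scatter) and lies beyond the scatter, so this position does not accept both groups alike. The change from (pyridin-3-yl)methyl to 1-phenylpropyl cannot be read, as compound 3 has no number. Open, going by these compounds, is where a plain benzyl or an unsubstituted cyclohexyl on this nitrogen would fall in this assay, which would help separate the ring from the propyl chain. No measurement shown accounts for the size of this step.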